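Moving the Thiophene Attachment on Compound 1

The source may hold more compounds than are shown below. What is called first, only, known or untested is meant among the compounds shown, and "the series" means these compounds.

Measured compounds:
compound 1 `N=C(N)N/N=C/c1c(-c2cccs2)nc2n1CCS2` — 22900 nM
compound 2 `N=C(N)N/N=C/c1c(-c2cccs2)nc2sccn12` — 8320 nM
compound 3 `N=C(N)N/N=C/c1c(-c2ccsc2)nc2sccn12` — 14800 nM

In a functional assay on cells (Cancer cell lines, Homo sapiens) for inhibition (on this read-out lower numbers stand for stronger inhibition of growth and higher numbers for weaker inhibition of growth), compound 1 gives 22900 nM, the highest of the three numbers; compound 3 lies nearest, within the scatter, while compound 2 lies furthest, beyond the scatter. Compound 4 `N=C(N)N/N=C/c1c(-c2ccsc2)nc2n1CCS2` has the same atoms as compound 1 joined differently: thiophen-3-yl in place of thiophen-2-yl on an aromatic carbon. Going by the values given here, one measured step bears on this change, a 1.8-fold higher number from compound 2 to compound 3 (0.25 log units; within the scatter), made on the core shared by compounds 2 and 3 and lying within the scatter. For compound 4 the expectation in this assay is therefore a small move towards a higher number, possibly none beyond the scatter. Compound 4 is expected to give about 35000 nM, from 15000 nM to 90000 nM, an expected step of a 1.5-fold higher number from compound 1 to compound 4 (0.18 log units; within the scatter).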

Compound 4, concentration for 50% growth inhibition: 28200 nM
Compound 4: middle estimate off by 1.2-fold (0.09 log units), on the high side, within the range that was stated.
By their numbers in this assay, from the lowest: compounds 2, 3, 1 and 4 (each within the scatter of the next, the first and the last beyond it).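

In this assay, moving the thiophene attachment on the core of compound 1 gives a 1.2-fold higher number from compound 1 to compound 4 (0.09 log units; within the scatter). The swap of thiophen-2-yl for thiophen-3-yl on this aromatic carbon has now been read on two cores, and on neither does the step leave the scatter: the same change on two cores in this assay, a 1.8-fold higher number (0.25 log units; within the scatter) from compound 2 to compound 3 and a 1.2-fold higher number (0.09 log units; within the scatter) from compound 1 to compound 4, 1.4-fold (0.16 log units) apart, within the scatter of two such steps

The compounds shown leave open how a group of another kind on this aromatic carbon, such as phenyl or a dimethylamino group, would stand in this assay on either core.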